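The source may hold more compounds than are shown below. What is called first, only, known or untested is meant among the compounds shown, and "the series" means these compounds.

Measured so far:
- Compound 1, `COc1cc(C(=O)N2CCCC2)nn1-c1ccccc1`, gives 29.2% in a functional assay on the whole organism (strain Wistar) for inhibition, with Rattus norvegicus as the target, read by paw edema, with stated times of 30 min and 3 h, at a dose of 100 mg/kg by the oral route; on this read-out higher numbers stand for more inhibition at the one dose given (going by the name of the read-out) and lower numbers for less inhibition.
- Compound 2, `CC(C)Oc1cc(C(=O)N(C)C)nn1-c1ccccc1`, gives 43.9% in this assay.
- Compound 3, `CCCCOc1cc(C(=O)NCC)nn1-c1ccccc1`, gives 0% in this assay.

Compound 3 stands lowest of the three numbers. Its nearest neighbour is compound 1, whose number is higher by a margin beyond the scatter, and the furthest is compound 2, higher still and also beyond the scatter. Compound 4, `CCCCNC(=O)c1cc(OCCCC)n(-c2ccccc2)n1`, has not yet been measured. It differs from compound 3 by ethyl in place of hydrogen on a saturated chain carbon, two bonds along the chain from an amide-type nitrogen, so that the ethylamino of compound 3 becomes a butylamino. Among the measured compounds shown here, no step between measured compounds is available to guide the size of this change. Since compound 3 gives 0%, the step from compound 3 to compound 4 is expected to be a number 10 percentage points higher from compound 3 to compound 4 (within the scatter), none beyond the scatter. Compound 4 is therefore estimated at 10%, in a range from 0% to 28%.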

Compound 4, a percentage reported as inhibition, in the whole organism at one dose (the size of the read-out at that dose, not a potency): 43.3%
The estimate for compound 4 lay 33.3 percentage points below the measured number; the whole stated range lies below it.
By their numbers in this assay, from the lowest: compound 3; then compound 1; then compounds 4 and 2 (each within the scatter of the next).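

In this assay, the change from ethylamino to butylamino gives a number 43.3 percentage points higher from compound 3 to compound 4 (beyond the scatter), a large step from adding ethyl at this one place on the amide chain. This shows that the read-out is sensitive to the length of this chain, with the rest of the molecule unchanged. Nothing given here accounts for the size of this step.

From the compounds shown here alone, whether a propyl chain gives an intermediate number remains open, as does whether a longer chain such as hexyl keeps the gain. Also open, going by these compounds, is how a terminal amine or carboxylic acid on this chain would read.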